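The source may report more compounds than this note shows. Statements on the series, on what has been measured and on what is new or still open speak of the compounds shown alone.

Measured so far:
compound 1, `COc1ccc(/C=C\c2cc(OC)c(OC)c(OC)c2)cc1OCc1ccc(CN[C@H](C(=O)O)[C@@H](C)O)cc1`: > 50000 nM
compound 2, `COc1ccc(/C=C\c2cc(OC)c(OC)c(OC)c2)cc1OCc1ccc(CN2CCCC[C@@H]2C(=O)O)cc1`: 42000 nM

Of the compounds shown here, two of this set have been tested in an ADME assay on HEK293 cells (Homo sapiens) for cytotoxicity, read by CCK-8 assay, with a stated time of 48 h; on this read-out higher numbers stand for weaker inhibition and lower numbers for stronger inhibition. Compound 1 `COc1ccc(/C=C\c2cc(OC)c(OC)c(OC)c2)cc1OCc1ccc(CN[C@H](C(=O)O)[C@@H](C)O)cc1` returns only the limit of the assay, > 50000 nM; this is a limit and not a number. Compound 2 `COc1ccc(/C=C\c2cc(OC)c(OC)c(OC)c2)cc1OCc1ccc(CN2CCCC[C@@H]2C(=O)O)cc1` gives 42000 nM in this assay. Compound 2 therefore holds the only number shown, the other value being a limit. Going by the values given here, the single measured step, an at least 1.1-fold lower number from compound 1 to compound 2 (0.07 log units; that floor lies within the scatter), runs against the limit of > 50000 nM in this assay, at which 1 of the 2 values shown sits, and lies within the scatter.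

Compound 3 `COc1ccc(/C=C\c2cc(OC)c(OC)c(OC)c2)cc1OCc1ccc(CNC(C)(C)C(=O)O)cc1` has not yet been measured. It differs from compound 2 as follows: (1-carboxy-1-methylethyl)amino in place of 2-carboxypiperidin-1-yl on a saturated chain carbon bound to an aromatic carbon. Among the compounds with values here, the one measured step bears on it in that it also exchanges a group on a saturated chain carbon bound to an aromatic carbon, and that step was not resolved beyond the scatter. For compound 3 the step is expected to be a 1.1-fold higher number from compound 2 to compound 3 (0.03 log units; within the scatter), within the scatter. Compound 3 is estimated at 45000 nM, with a range from 20000 nM to 100000 nM, and a fair chance that the assay again reports only a limit.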

Compound 3, half-maximal inhibitory concentration: > 50000 nM
Compound 3 ended at the assay's limit; the forecaster's own chance of this, stated with the estimate: 50%; at least 1.1-fold (0.04 log units) between middle value and limit.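

Exchanging the 2-carboxypiperidin-1-yl group for (1-carboxy-1-methylethyl)amino on the saturated chain carbon bound to an aromatic carbon removes the ring and the defined stereocentre, and in this assay this gives an at least 1.1-fold higher number from compound 2 to compound 3 (0.07 log units; that floor lies within the scatter). This second exchange at the same place therefore also shows no change resolved beyond the scatter, so neither the ring nor its removal is shown to matter in this assay. The groups without a ring, in compound 1 and compound 3, both return a limit and not a number, and the step between these two cannot be read, leaving compound 2, with its ring, as the only compound with a number: the limit of > 50000 nM in this assay, at which 2 of the 3 values shown sit.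

Going by these compounds, all three compounds carry a carboxylic acid at this place, so it remains open whether any group there can move the read-out beyond the scatter. A simple amine or an amide in place of the carboxylic acid, on the same core, would bear on that question, and the compounds shown do not say how far past the limit compound 1 and compound 3 lie.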